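Pyrazoline series: nitrophenyl to methoxyphenyl swap

The source may hold more compounds than are shown below. What is called first, only, known or untested is meant among the compounds shown, and "the series" means these compounds.

Measured compounds and values:
compound 1, `CC(=O)N1N=C(c2ccco2)CC1c1ccc(Cl)cc1`: 39000 nM in a functional assay on PC-3 cells (Homo sapiens) for cytotoxicity, read by sulforhodamine B assay, with a stated time of 48 h; on this read-out higher numbers stand for weaker inhibition and lower numbers for stronger inhibition
compound 2, `O=CCN1N=C(c2ccc3ccccc3c2)CC1c1ccccc1[N+](=O)[O-]`: 3010 nM in this assay
compound 3, `COc1ccc(C2CC(c3ccc4ccccc4c3)=NN2CC=O)c(OC)c1OC`: 610 nM in this assay

On the three numbers available, compound 2 stands second highest. Its nearest neighbour is compound 3, which gives a lower number, a gap beyond the scatter; furthest is compound 1, which gives a higher number, also beyond the scatter. Within the data shown here, no pair among the measured compounds differs in only one place, so no single-point step has been observed in this assay.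

Compound 4, `COc1ccc(C2CC(c3ccc4ccccc4c3)=NN2CC=O)cc1`, is the next candidate. It differs from compound 2 by 4-methoxyphenyl in place of 2-nitrophenyl on a saturated ring carbon. Among the measured compounds shown here, compound 3 carries a trimethoxyphenyl on the same saturated ring carbon and shares the naphthyl and formylmethyl groups of compound 2, so the only guide is that compound 2 gives 3010 nM while compound 3 gives 610 nM. The step is therefore expected to be a 2.0-fold lower number from compound 2 to compound 4 (0.30 log units; within the scatter), a modest move toward a lower number. Compound 4 is estimated at 1500 nM, with a range from 500 nM to 4500 nM.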

Compound 4, half-maximal inhibitory concentration: 4530 nM
Compound 4: middle estimate off by 3.0-fold (0.48 log units), on the low side, and the stated range ends below it.
By their numbers in this assay, from the lowest: compound 3; then compounds 2 and 4 (each within the scatter of the next); then compound 1.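

In this assay, among these compounds, the exchange of 2-nitrophenyl for 4-methoxyphenyl on the saturated ring carbon gives a 1.5-fold higher number from compound 2 to compound 4 (0.18 log units; within the scatter), the first single-place step, and this position tolerates a change of aryl substituent with no shift that can be told from the scatter. The low number of compound 3 at 610 nM, with its trimethoxyphenyl on the same carbon, is not reached with a single methoxy group: compound 4 gives 4530 nM, so one methoxy group on the phenyl is not enough to match compound 3 in this assay. No measurement at hand bears on why the nitrophenyl and methoxyphenyl compounds read alike.

The compounds shown leave open whether the number of methoxy groups or their placement on the phenyl separates compound 3 from compound 4, since a dimethoxyphenyl would be needed to tell these apart. From the compounds shown here alone, it is also open whether this position responds at all to a group of another kind on the phenyl, such as a hydroxyl, a dimethylamino group or a carboxylic acid.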